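Methyl for methoxy on the benzyl ring of compound 1

The source may report more compounds than this note shows. Statements on the series, on what has been measured and on what is new or still open speak of the compounds shown alone.

Compound 1: `COc1cc(F)c(CN2C(=O)N(c3ccc(OC)c(OC)c3)S(=O)(=O)c3ccccc32)c(Cl)c1`; 0.398 nM
Compound 2: `COc1cc(N2C(=O)N(Cc3c(F)cc(F)cc3F)c3ccccc3S2(=O)=O)cc(OC)n1`; 15.9 nM
Compound 3: `COc1cc(F)c(CN2C(=O)N(c3cnc(OC)c(OC)c3)S(=O)(=O)c3ccccc32)c(F)c1`; 2.51 nM

In an assay on isolated protein for displacement of a labelled ligand from Orexin/Hypocretin receptor type 1 (Homo sapiens), with a stated time of 90 min (a lower number here means a stronger inhibitor, a higher number a weaker inhibitor), compound 1 gives 0.398 nM, the lowest number of the three measured. Compound 3 gives 2.51 nM, and compound 2 gives 15.9 nM; both gaps to compound 1 lie beyond the scatter, so compound 1 is the strongest inhibitor of the three in this assay. Compound 4, `COc1ccc(N2C(=O)N(Cc3c(F)cc(C)cc3Cl)c3ccccc3S2(=O)=O)cc1OC`, has not been measured. It differs from compound 1 in one place: methyl in place of methoxy on an aromatic carbon. Among the measured compounds shown here, no step between measured compounds shows this particular change, so there is nothing measured to lean on directly. A change of this kind, a small group swapped for a small group at a single aromatic carbon of the benzyl ring, is expected to move the number little, and the step from compound 1 to compound 4 in this assay is estimated to be a 1.5-fold higher number from compound 1 to compound 4 (0.18 log units; within the scatter), within or close to the scatter. On that basis compound 4 is expected to give about 0.6 nM in this assay, with a range from 0.2 nM to 2 nM.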

Compound 4, inhibition constant: 6.31 nM
The estimate for compound 4 lay 11-fold (1.02 log units) below the measured number; measured number above the stated range.
By their numbers in this assay, from the lowest: compound 1; then compound 3; then compound 4; then compound 2.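

Exchanging methoxy for methyl at the ring carbon para to a large group gives, in this assay, a 16-fold higher number from compound 1 to compound 4 (1.20 log units; beyond the scatter), so the group at this carbon of the benzyl ring has a large bearing on the number. Among the compounds shown here, this is the first direct reading of a single change, as compound 1, compound 2 and compound 3 differ from one another in more than one place and gave no step. The change removes one heavy atom and the one hydrogen-bond acceptor counted for methoxy, but nothing measured here ties the step to either of these or explains it.

The compounds shown leave open whether the step follows from losing the oxygen or from the exchange of the whole group, a question that a hydroxy group, an ethoxy group or an amine at this carbon would bear on. They also leave open whether the same step would appear with the other benzyl and aryl groups, such as those of compound 3, which also carries methoxy at this carbon but has no methyl partner here.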